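From 1-hydroxyethyl to furan-2-yl on a shared core

The source may report more compounds than this note shows. Statements on the series, on what has been measured and on what is new or still open speak of the compounds shown alone.

Measured so far:
- compound 1 `Brc1cnn2c(NCc3cccnc3)cc(C3CC3)nc12` gives 1500 nM here
- compound 2 `CC(O)c1cc(NCc2cccnc2)n2ncc(Br)c2n1` gives 1400 nM here
- compound 3 `Clc1ccccc1-c1cc(NCc2cccnc2)n2ncc(Br)c2n1` gives 500 nM; 500 nM (2 entries) here

All three numbers come from a functional assay on cells (Homo sapiens), read by thymidine incorporation (on this read-out higher numbers stand for weaker inhibition and lower numbers for stronger inhibition), and the compounds differ only in the group on one aromatic carbon of the shared core. Going by the values given here, the only measured step, a 1.1-fold lower number from compound 1 to compound 2 (0.03 log units; within the scatter), stays within the scatter, so compound 2 stands level with compound 1. Compound 3 shows a lower number than both. The next compound, compound 4 `Brc1cnn2c(NCc3cccnc3)cc(-c3ccco3)nc12`, has furan-2-yl in place of 1-hydroxyethyl on an aromatic carbon, and the counted change is furan-2-yl in place of 1-hydroxyethyl on an aromatic carbon here. The cyclopropyl to 1-hydroxyethyl step involves no aromatic group, so it offers little guidance. Compound 3, at 500 nM; 500 nM (2 entries), carries an aromatic ring at that place, as compound 4 does, so a lower number is expected, though on this single example. The expected change is a 2.0-fold lower number from compound 2 to compound 4 (0.30 log units; within the scatter), a modest move. For compound 4 the estimate is 700 nM, with a range from 250 nM to 2000 nM in this measurement.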

Compound 4, half-maximal inhibitory concentration: 15200 nM
The estimate for compound 4 lay 22-fold (1.34 log units) below the measured number, outside the stated range (above it).
By their numbers in this assay, from the lowest: compounds 2 and 1 (each within the scatter of the next); then compound 4.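

Placing furan-2-yl on this aromatic carbon gives an 11-fold higher number from compound 2 to compound 4 (1.04 log units; beyond the scatter) and a 10-fold higher number from compound 1 to compound 4 (1.01 log units; beyond the scatter) in this assay so this position can respond strongly to its group, which the level pair of cyclopropyl and 1-hydroxyethyl gave no sign of. An aromatic ring here does not by itself bring a low number: compound 4 gives 15200 nM while compound 3, also aromatic at this place, gives 500 nM; 500 nM (2 entries) in the same test. The data shown offer no measured explanation for this large rise.

From the compounds shown here alone, it remains open whether the rise belongs to furan-2-yl alone or to five-membered aromatic rings more widely, which a thiophen-2-yl group could test. An unsubstituted phenyl ring or a small amine such as dimethylamino at this place would also show how far the position tolerates other groups.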